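A few compounds are considered here, and "the series" means these few. Any claim that something is new, unique, unknown or untested is made for them only; others in the source may bear on it.

Working notes on the series, read in an ADME assay on Vero cells (Chlorocebus sabaeus) for cytotoxicity; on this read-out lower numbers stand for stronger inhibition and higher numbers for weaker inhibition. Compound 1 (`CCCCCCCCCCCCC(=O)c1cc(O)c(O)c(O)c1`) gives > 1000 nM, which is a limit of the assay. Compound 2 (`CCCCCCCCCCCCCCC(=O)c1cc(O)c(O)c(O)c1`) gives > 1000 nM, again only a limit. Within the data shown here, the single measured step, a step that the two limits leave unreadable from compound 1 to compound 2, has no readable size, and the evidence amounts to the limit of > 1000 nM in this assay, at which 2 of the 2 values shown sit. Compound 3 (`CCCCCCCCCCCCCCCCC(=O)c1cc(O)c(O)c(O)c1`) differs from compound 2 by ethyl in place of hydrogen on a saturated chain carbon, ten or more bonds along the chain from a carbonyl carbon, the same ethyl in place of hydrogen as in that step. Among the measured compounds shown here, with no sized step to go on, no change beyond the scatter is expected, and the estimated step is a step that the limit leaves unreadable from compound 2 to compound 3. For compound 3 the expected value is 2000 nM, with an estimated range of 1000 nM to 10000 nM.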

Compound 3, half-maximal inhibitory concentration: > 1000 nM
Compound 3: only a limit was reported; the forecaster's own chance of this, stated with the estimate: 85%; the middle value is on the limit's open side.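

No step among compound 1, compound 2 and compound 3 can be read, as each result is only a limit: the limit of > 1000 nM in this assay, at which 3 of the 3 values shown sit.

The compounds shown leave open whether the length of the chain changes the read-out in this assay at all.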